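Changing a saturated ring on the core, permeability near the ceiling

A few compounds are considered here, and "the series" means these few. Any claim that something is new, unique, unknown or untested is made for them only; others in the source may bear on it.

This study follows how freely small molecules pass an artificial membrane, measured in an ADME assay for permeability, using PAMPA, with a stated time of 30 min, at pH 7.4; on this read-out lower numbers stand for lower permeability and higher numbers for higher permeability. Compound 1 `N=c1c2c(-c3ccccc3)c(-c3ccccc3)n(Cc3ccccc3)c2ncn1CCNc1ccncc1` gives 445 10^-6 cm/s in this assay. Compound 2 `COc1ccc(-c2c(-c3ccc(OC)cc3)n(Cc3ccccc3)c3ncn(CC4CCOC4)c(=N)c23)cc1` is reported only as a limit of the assay, > 1000 10^-6 cm/s, so no exact number is known for it. In this assay compound 2 sits at the limit of > 1000 10^-6 cm/s in this assay, at which 1 of the 2 values shown sits.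

Compound 3 `COc1ccc(-c2c(-c3ccc(OC)cc3)n(Cc3ccccc3)c3ncn(C4CCOCC4)c(=N)c23)cc1` has not yet been measured. It differs from compound 2 in one place: oxan-4-yl in place of (oxolan-3-yl)methyl on an aromatic nitrogen. The two have the same atoms, joined differently, so nothing is added or lost, only rearranged.

Among the compounds with values here, no step between two measured compounds is available here to guide the size of the effect. Compound 2 stands at the upper edge of what this assay can read, and the expected step from compound 2 to compound 3, a number no higher from compound 2 to compound 3 (the limit leaves the size open), is none beyond the usual scatter. Compound 3 is therefore expected to give about 1000 10^-6 cm/s in this assay, within a range from 400 10^-6 cm/s to 1500 10^-6 cm/s, and it may well again be reported only as a limit rather than a number.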

Compound 3, apparent permeability: > 1000 10^-6 cm/s
Compound 3: no number, only a limit (the forecaster's own chance of this, stated with the estimate: 70%); the middle value lies on the limit itself.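

In this assay compound 3 is reported only as a limit, > 1000 10^-6 cm/s. Compound 2 is also reported only as a limit, so no step can be read from compound 2 to compound 3: the limit of > 1000 10^-6 cm/s in this assay, at which 2 of the 3 values shown sit.

The compounds shown leave open whether oxan-4-yl in place of (oxolan-3-yl)methyl changes the read-out at all, and by how much.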